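The source may report more compounds than this note shows. Statements on the series, on what has been measured and on what is new or still open speak of the compounds shown alone.

Compound 1 `CCOC(=O)C1=C(C)N(c2ccccc2)C=CC1c1ccccc1` gives -37.1% in a functional assay for inhibition, using microsomes, tested at 200 ug/mL; on this read-out lower numbers stand for a stronger effect and higher numbers for a weaker effect at the one concentration tested.
Compound 2 `CCOC(=O)C1=C(C)N(c2ccc(C)cc2)C=CC1c1ccccc1` gives -38.4%.
Compound 3 `CCOC(=O)C1=C(C)N(c2ccc(Br)cc2)C=CC1c1ccccc1` gives -32.1%.

Among these three numbers compound 1 stands second highest. Its nearest neighbour is compound 2, with a number 1.3 percentage points lower from compound 1 to compound 2 (within the scatter), and its furthest is compound 3, with a number 5 percentage points higher from compound 1 to compound 3 (within the scatter). Compound 2 and compound 3 are separated by a number 6.3 percentage points higher from compound 2 to compound 3 (within the scatter). All three steps stay within the scatter of repeated measurements, so these three compounds cannot be told apart on this read-out.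

Compound 4 `CC1=C(C(=O)OC(C)(C)C)C(c2ccccc2)C=CN1c1ccccc1` has not yet been measured. It differs from compound 1 in one place: tert-butyl in place of ethyl on an oxygen next to a carbonyl group. For the measured compounds named here, each measured step swaps a group on an aromatic carbon, while this change swaps the group on an oxygen next to a carbonyl group, so none of the measured steps bears on it. Going by the values given here, with no comparable step to draw on, the plain expectation is a step no larger than the scatter, in either direction. Compound 4 is therefore estimated at -37%, with a range from -55% to -19%. That estimate means an expected step of a number 0.1 percentage points higher from compound 1 to compound 4 (within the scatter), within the scatter.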

Compound 4, a percentage reported as activity, at one concentration (the size of the read-out at that concentration, not a potency): -42.1%
Compound 4: the middle estimate sits 5.1 percentage points above what was measured; low and high end bracket the measured number.
By their numbers in this assay, from the lowest: compounds 4, 2, 1 and 3 (each within the scatter of the next).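

For the compounds shown here, the earlier compounds changed only a group on an aromatic carbon, so compound 4 gives the first reading for a change on an oxygen next to a carbonyl group. In this assay, tert-butyl, with 4 heavy atoms, in place of ethyl, with 2, gives a number 5 percentage points lower from compound 1 to compound 4 (within the scatter), so on this read-out this change cannot be told apart from no change at all. No measurement is available that could link this step to any property of either group.

Going by these compounds, it remains open whether a different group at this place, such as a longer chain, or a carboxylic acid in place of the whole ethoxycarbonyl group, would move the number beyond the scatter. Also open, on these data alone, is what tert-butyl at this oxygen gives when combined with the methyl of compound 2 or the bromo of compound 3.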